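Swapping Bromines for a Methoxy on the Hydrazone Aryl

The compounds below may be only part of what the source reports. "The series", "measured", "known", "first", "only" and "open" are said of these compounds alone.

Compound 3, `CN(C)CCn1cnnc1-c1cc(Oc2ccc(NC(=O)N/N=C/c3cc(Br)c(O)c(Br)c3)cc2F)ccn1`, carries a 3,5-dibromo-4-hydroxyphenyl on a carbon with a double bond to nitrogen. In a functional assay on U-87MG ATCC cells (Homo sapiens) for cytotoxicity, read by MTT assay, with a stated time of 72 h (on this read-out lower numbers stand for stronger inhibition and higher numbers for weaker inhibition), compound 3 gives > 100000 nM, which is a limit of the assay and not a number. Compound 1, `CN(C)CCn1cnnc1-c1cc(Oc2ccc(NC(=O)N/N=C/c3ccc(O)c(O)c3)cc2F)ccn1`, also stops at a limit in this assay, > 100000 nM. Compound 2, `CN(C)CCn1cnnc1-c1cc(Oc2ccc(NC(=O)N/N=C/c3c(O)ccc4ccccc34)cc2F)ccn1`, gives 620 nM in this assay. The steps of an at least 160-fold lower number from compound 1 to compound 2 (2.20 log units; beyond the scatter) and an at least 160-fold higher number from compound 2 to compound 3 (2.20 log units; beyond the scatter) are large, whereas a step that the two limits leave unreadable from compound 1 to compound 3 cannot be read. Compound 4, `COc1cc(/C=N/NC(=O)Nc2ccc(Oc3ccnc(-c4nncn4CCN(C)C)c3)c(F)c2)ccc1O`, differs from compound 3 by 4-hydroxy-3-methoxyphenyl in place of 3,5-dibromo-4-hydroxyphenyl on a carbon with a double bond to nitrogen. Because the limit of > 100000 nM in this assay, at which 2 of the 3 values shown sit, holds both phenyl-bearing compounds, compound 4 is expected to stay near that limit, so the step of a number no higher from compound 3 to compound 4 (the limit leaves the size open) is expected to be none beyond the scatter. Compound 4 is therefore estimated at 100000 nM, between 10000 nM and 300000 nM.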

Compound 4, half-maximal inhibitory concentration: > 100000 nM
Compound 4: no number, only a limit; the forecaster's own chance of this, stated with the estimate: 65%; the middle value lies on the limit itself.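

Compound 4 also stops at a limit in this assay, and that limit is not a number, so its steps to compound 1 and compound 3 cannot be read. Replacing the 2-hydroxynaphthalen-1-yl with 4-hydroxy-3-methoxyphenyl gives an at least 160-fold higher number from compound 2 to compound 4 (2.20 log units; beyond the scatter). A third substituted phenyl on this carbon therefore ends in the same place: the limit of > 100000 nM in this assay, at which 3 of the 4 values shown sit.

From the compounds shown here alone, what stays open is whether any phenyl at this position can give a measurable value. A phenyl carrying an amine or a carboxylic acid, or a naphthalen-1-yl without its hydroxyl, would test how far this pattern holds.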